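The source may report more compounds than this note shows. Statements on the series, on what has been measured and on what is new or still open speak of the compounds shown alone.

Working notes on the series around compound 1 `Cn1nnc(-c2sc(-c3cccc(F)c3)nc2O)n1`. In an assay on HEK293 cells for inhibition of transient receptor potential cation channel subfamily M member 8 (Homo sapiens), read by FLIPR, with stated times of 5 min and 3 min (a higher number here means a weaker inhibitor, a lower number a stronger inhibitor), compound 1 gives 214 nM, the lowest of the two numbers at hand. Compound 3 `CCn1nnc(-c2sc(-c3cccc(N(C)C)c3)nc2O)n1`, the nearest neighbour, gives 4770 nM in this assay, a gap well beyond the scatter. Compound 2 `O=C(c1sc(-c2cccc(F)c2)nc1O)N1CCCOC1` reaches only a limit of this assay, > 100000 nM, and no number; this is the limit of > 100000 nM in this assay, at which 1 of the 3 values shown sits.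

Compound 4 `Cc1nc(-c2sc(-c3cccc(F)c3)nc2O)no1` has not yet been measured in this assay. Its change from compound 1 is 5-methyl-1,2,4-oxadiazol-3-yl in place of 2-methyl-2H-tetrazol-5-yl on an aromatic carbon. The groups that leave and enter match in heavy-atom count, and each is a five-membered aromatic ring carried by a methyl; the entering ring holds one hetero atom and one hydrogen-bond acceptor fewer. For the measured compounds named here, no measured pair in this set isolates such a swap, so the step cannot be read from the data and is judged from the change alone. A small step is expected, within or only just beyond the scatter, toward a somewhat higher number; the expected step is a 2.1-fold higher number from compound 1 to compound 4 (0.32 log units; beyond the scatter). Compound 4 is estimated at 450 nM in this assay, with a range from 120 nM to 1800 nM.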

Compound 4, half-maximal inhibitory concentration: 1800 nM
Compound 4: the middle estimate sits 4.0-fold (0.60 log units) below what was measured; the measured number falls inside the stated range.
By their numbers in this assay, from the lowest: compound 1; then compound 4; then compound 3. At a limit, above all of these: compound 2.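

In this assay, for the compounds shown here, the swap on the aromatic carbon next to the ring sulfur gives the first step that can be read at this position: an 8.4-fold higher number from compound 1 to compound 4 (0.92 log units; beyond the scatter). The two groups match in heavy-atom count and each is a five-membered aromatic ring carrying a methyl, so the response at this position is not set by heavy-atom count alone. With the rest of the core of compound 1 unchanged, the 2-methyl-2H-tetrazol-5-yl is not interchangeable here with the 5-methyl-1,2,4-oxadiazol-3-yl, though the result is a single pair and no trend across rings. Nothing measured here accounts for the size of this step.

Open, on these data alone, is how a 5-methyl-1,3,4-oxadiazol-2-yl or a tetrazole with no methyl would stand at this position. Also open, as far as these compounds go, is whether the same swap would give a similar step with a group other than the fluorophenyl on the core.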